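From cyclobutyl to cyclopentyl on the shared core

This account rests on a few compounds, and the source may have more. Where it says the series, first, only, none or still open, it means among the compounds named here.

In a functional assay on CCRF-CEM cells (Homo sapiens) for cytotoxicity, with a stated time of 72 h (a lower number here means a stronger inhibitor, a higher number a weaker inhibitor), the propyl compound 1 (`CCCc1ncnc2c1ncn2[C@@H]1O[C@H](CO)[C@@H](O)[C@H]1O`) gives 6800 nM as its half-maximal inhibitory concentration, the butyl compound 2 (`CCCCc1ncnc2c1ncn2[C@@H]1O[C@H](CO)[C@@H](O)[C@H]1O`) gives 49000 nM and the cyclobutyl compound 3 (`OC[C@H]1O[C@@H](n2cnc3c(C4CCC4)ncnc32)[C@H](O)[C@@H]1O`) gives 7000 nM in the same read-out. Compound 3 thus sits level with compound 1 at the low end of the three numbers, and compound 2 stands apart with the highest.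

The next structure, compound 4 (`OC[C@H]1O[C@@H](n2cnc3c(C4CCCC4)ncnc32)[C@H](O)[C@@H]1O`), has cyclopentyl in place of cyclobutyl on an aromatic carbon of the shared core. Going by the values given here, no measured step changes ring size, so the evidence is indirect. Butyl in place of propyl gave a 7.2-fold higher number from compound 1 to compound 2 (0.86 log units; beyond the scatter) and so a modest rise. Cyclobutyl in place of butyl gave a 7.0-fold lower number from compound 2 to compound 3 (0.85 log units; beyond the scatter) and so a modest fall of similar size. Cyclobutyl in place of propyl gave a 1.0-fold higher number from compound 1 to compound 3 (0.01 log units; within the scatter) and so nothing beyond the scatter. Of these, only a 7.2-fold higher number from compound 1 to compound 2 (0.86 log units; beyond the scatter) enlarges a group, so a smaller step in the same direction is expected here. The expected step is a 2.3-fold higher number from compound 3 to compound 4 (0.36 log units; beyond the scatter) and it would be modest. Compound 4 is estimated at 16000 nM with an expected range from 5000 nM to 50000 nM in this assay until it is measured.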

Compound 4, half-maximal inhibitory concentration: 16000 nM
Compound 4: middle estimate and measured number agree at the digits printed; the measured number falls inside the stated range.
By their numbers in this assay, from the lowest: compounds 1 and 3 (each within the scatter of the next); then compound 4; then compound 2.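

Among the compounds shown, this is the only step that changes ring size at the aromatic carbon next to the ring nitrogen, and in this assay the change from cyclobutyl to cyclopentyl is a modest rise (a 2.3-fold higher number from compound 3 to compound 4 (0.36 log units; beyond the scatter)), the same direction as the lengthening of the open chain from propyl to butyl. It also shows that a carbocycle at this position is not always equivalent to the propyl chain: cyclobutyl was level with propyl (a 1.0-fold higher number from compound 1 to compound 3 (0.01 log units; within the scatter)), whereas cyclopentyl stands beyond the scatter from it (a 2.4-fold higher number from compound 1 to compound 4 (0.37 log units; beyond the scatter)). Cyclopentyl nevertheless remains on the lower side of the butyl chain (a 3.1-fold lower number from compound 2 to compound 4 (0.49 log units; beyond the scatter)), so compound 2 still has the highest number of the four, and compound 4 falls between it and the pair of compounds 1 and 3.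

Nothing available here accounts for the rise with ring size or for the gap between cyclopentyl and butyl. Open too, on these data alone, is whether cyclohexyl would continue the rise, and how a cyclopropyl ring, a phenyl ring or an amine would fare at this carbon of the shared core.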